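The source may hold more compounds than are shown below. What is called first, only, known or untested is meant among the compounds shown, and "the series" means these compounds.

Compound 2 `O=c1nc(-c2ccccc2)c2cc(-c3ccccc3)ccc2[nH]1` stands only at a limit of the assay: in an ADME assay on L6 cells (Rattus norvegicus) for cytotoxicity, read by fluorescence and resazurin assay, with a stated time of 72 h (a higher number here means that more compound is needed for the effect, a lower number that less compound is needed), compound 2 gives > 50000 nM, which is a limit and not a number. Compound 1 `Cc1ccncc1-c1ccc2[nH]c(=O)nc(-c3ccccc3)c2c1` likewise reaches only a limit in this assay, > 50000 nM. Among the compounds with values here, the single measured step, a step that the two limits leave unreadable from compound 1 to compound 2, is therefore unreadable, and the evidence amounts to the limit of > 50000 nM in this assay, at which 2 of the 2 values shown sit. Compound 3 `N#Cc1ccc(-c2ccc3[nH]c(=O)nc(-c4ccccc4)c3c2)cc1` differs from compound 2 by cyano in place of hydrogen on an aromatic carbon. With no readable step to draw on, the expected step is a step that the limit leaves unreadable from compound 2 to compound 3, nothing beyond the scatter. For compound 3 in this assay the estimate is 60000 nM, between 30000 nM and 150000 nM.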

Compound 3, half-maximal effective concentration: > 50000 nM
Compound 3: no number, only a limit; the forecaster's own chance of this, stated with the estimate: 80%; the middle value is on the limit's open side.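

Like compound 1 and compound 2, compound 3 reaches only a limit in this assay, so no step among these compounds can be read. The compounds shown leave open whether any of these groups changes the value in this assay, and by how much.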